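From Methyl to Isopropyl in an NF-kappa-B Inhibition Series

A few compounds are considered here, and "the series" means these few. Any claim that something is new, unique, unknown or untested is made for them only; others in the source may bear on it.

Compound 1 `Cc1ccc(Nc2ccc3c(c2)C(=O)N(C2CCC(=O)NC2=O)C3=O)cc1` gives 5% in an assay on FRT-Jurkat cells for inhibition of nuclear factor NF-kappa-B complex (Homo sapiens), read by flow cytometry, with a stated time of 24 h, tested at 10 uM (on this read-out lower numbers stand for less inhibition and higher numbers for more inhibition at the one concentration tested (going by the name of the read-out)), the second highest of the three numbers measured. Compound 3 `CC(=O)c1ccc(Nc2cccc3c2C(=O)N(C2CCC(=O)NC2=O)C3=O)cc1` gives 2%, within the scatter of compound 1, while compound 2 `CC(C)(C)c1ccc(Nc2cccc3c2C(=O)N(C2CCC(=O)NC2=O)C3=O)cc1` gives 36%, well beyond it. Compound 4 `CC(C)c1ccc(Nc2ccc3c(c2)C(=O)N(C2CCC(=O)NC2=O)C3=O)cc1` differs from compound 1 in one place: isopropyl in place of methyl on an aromatic carbon. For the measured compounds named here, the only measured single step, a number 34 percentage points lower from compound 2 to compound 3 (beyond the scatter), sits on compounds whose shared core differs from that of compound 1, so it bears only loosely; still, there the larger alkyl group, tert-butyl, carried the higher number. Growing methyl to isopropyl is a smaller change of the same kind, so a modest rise is expected for compound 4, a number 10 percentage points higher from compound 1 to compound 4 (within the scatter), with wide uncertainty. Compound 4 is estimated at 15%, expected between 0% and 40%.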

Compound 4, a percentage reported as inhibition, at one concentration (the size of the read-out at that concentration, not a potency): 11%
Compound 4: middle estimate off by 4 percentage points, on the high side; low and high end bracket the measured number.
By their numbers in this assay, from the lowest: compounds 3, 1 and 4 (each within the scatter of the next); then compound 2.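

On the core of compound 1, isopropyl in place of methyl on an aromatic carbon, para to a large group, gives a number 6 percentage points higher from compound 1 to compound 4 (within the scatter). For the compounds shown here, this is the first direct reading of an alkyl change at this position, and the move from 4-methylphenyl to 4-isopropylphenyl leaves the two compounds indistinguishable at the one concentration tested. Nothing available here explains this result.

From the compounds shown here alone, what an amine, a carboxylic acid or a longer alkyl chain would give at this place remains open. So does how tert-butyl would read on this core.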